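Chloro Gives Way to Methyl in Compound 2

The source may hold more compounds than are shown below. What is called first, only, known or untested is meant among the compounds shown, and "the series" means these compounds.

In a functional assay on U-251 cells (Homo sapiens) for inhibition, read by sulforhodamine B assay, with a stated time of 48 h (on this read-out higher numbers stand for weaker inhibition of growth and lower numbers for stronger inhibition of growth), compound 1 `CCOC(=O)c1nn(-c2ccc(Cl)cc2)c(-c2ccc(Cl)cc2)c1CNC(C)(C)C` has entries reading 6400 nM; > 519000 nM (2 entries). The entry of compound 1 that carries a sign is a limit of the assay, not a number. Compound 2 `CC(C)(C)NCc1c(C(=O)O)nn(-c2ccc(Cl)cc2)c1-c1ccc(Cl)cc1` stands at 518000 nM, the only number shown for it in this assay, and one further entry for compound 2 gives no single number. Compound 3 `Cc1ccc(-c2c(CNC(C)(C)C)c(C(=O)O)nn2-c2ccc(Cl)cc2)cc1` carries methyl in place of chloro on an aromatic carbon, para to a large group, so that 4-chlorophenyl becomes 4-methylphenyl: methyl in place of chloro on an aromatic carbon. For the measured compounds named here, no measured pair isolates this exchange, so no change beyond the usual scatter is expected in this assay, and the expectation stays anchored on compound 2 at 518000 nM. The expected change is a 1.2-fold lower number from compound 2 to compound 3 (0.06 log units; within the scatter). The estimate for compound 3 is 450000 nM, with an expected range of 150000 nM to 600000 nM.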

Compound 3, concentration for 50% growth inhibition: > 629000 nM
Compound 3 ended at the assay's limit (the forecaster's own chance of this, stated with the estimate: 45%); middle value at least 1.3-fold (0.14 log units) from the limit.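

In this assay, for the compounds shown here, methyl in place of chloro on an aromatic carbon, para to a large group, gives the first reading for this position: an at least 1.2-fold higher number from compound 2 to compound 3 (0.08 log units; that floor lies within the scatter). Compound 3 gives > 629000 nM, which is a limit of the assay and not a number. The exchange of 4-chlorophenyl for 4-methylphenyl therefore shows no gain in inhibition of growth at this position, and how far the true value of compound 3 lies from that limit cannot be told.

The compounds shown leave open whether a methoxy group or a fluorine atom at this position would give a reading clear of the limit. They also leave open whether the same exchange would act alike on the ethyl ester carried by compound 1.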